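A few compounds are considered here, and "the series" means these few. Any claim that something is new, unique, unknown or untested is made for them only; others in the source may bear on it.

Measured so far in a functional assay on HT-29 cells (Homo sapiens) for antiproliferative activity, read by MTT assay, with a stated time of 96 h; on this read-out higher numbers stand for weaker inhibition and lower numbers for stronger inhibition:
- compound 1 `O=C1NC(=O)C2(CSC3=C2C(=O)c2ncccc2C3=O)N1`: 190 nM; 180 nM; 190 nM (3 entries)
- compound 2 `O=C1C2=C(C(=O)c3ncccc31)C1(CS2)NC(=O)N(c2ccc([N+](=O)[O-])cc2)C1=O`: 250 nM

Repeat runs of compound 1 agree closely, as the several entries of compound 1 in this assay, 190 nM; 180 nM; 190 nM (3 entries) shows. Compound 2 has a single number, 250 nM, and one further entry that gives no single number. That number lies within the usual scatter of the value for compound 1, so these two compounds cannot be ranked in this assay.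

The next compound to be tested is compound 3 `CN(C)c1ccc(N2C(=O)NC3(CSC4=C3C(=O)c3ncccc3C4=O)C2=O)cc1`. It differs from compound 2 at one place, changing 4-nitrophenyl to 4-(dimethylamino)phenyl: dimethylamino in place of nitro on an aromatic carbon. In words, dimethylamino stands in place of nitro on an aromatic carbon.

For the measured compounds named here, no measured pair here shows a change of this kind, so there is no direct guide to its size or direction. Going by the values given here, the only anchor is compound 2 at 250 nM, and no shift beyond the usual scatter is expected in this assay. The expected change is a 1.1-fold lower number from compound 2 to compound 3 (0.06 log units; within the scatter). For compound 3 the estimated value is 220 nM, with an expected range from 70 nM to 700 nM.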

Compound 3, half-maximal inhibitory concentration: 20 nM
Beside the measured number, compound 3's estimate is 11-fold (1.04 log units) above it; measured number below the stated range.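

Until now nothing showed that the group on this aromatic ring could strongly affect the result, but in this assay placing dimethylamino where nitro stood, para to a large group, gives a 13-fold lower number from compound 2 to compound 3 (1.10 log units; beyond the scatter) on the same core. This position therefore responds strongly to what it carries, even though nitro and dimethylamino have the same heavy-atom count, so that count alone does not separate them. The step is also far wider than the spread between repeat runs, so run-to-run variation does not account for it, as the closest available check shows: the several entries of compound 1 in this assay, 190 nM; 180 nM; 190 nM (3 entries).

A single step cannot show whether the lower number comes from losing nitro, from gaining dimethylamino or from both, and nothing here explains why the swap has such a large effect. A plain hydrogen, a methoxy group, a primary amine or a diethylamino group at the same place would help separate these possibilities and show whether the effect extends beyond this one pair.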